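Exchanging Vinyl for Ethynyl on the Shared Core

A few compounds are considered here, and "the series" means these few. Any claim that something is new, unique, unknown or untested is made for them only; others in the source may bear on it.

Of the compounds shown here, three built on one shared core have been tested in an assay on HEK293 cells for binding affinity to 5-hydroxytryptamine receptor 7 (Homo sapiens), read by radioligand binding, tested at 1 uM; a lower number here means less inhibition, a higher number more inhibition at the concentration tested (going by the name of the read-out). Compound 1 `CN1CCCN(CCn2ccc3ccc(Cl)cc32)CC1` gives 85%. Compound 2 `CN1CCCN(CCn2ccc3ccc(C(F)(F)F)cc32)CC1` gives 89%, which amounts to a number 4 percentage points higher from compound 1 to compound 2 (within the scatter). Compound 3 `C=Cc1ccc2ccn(CCN3CCCN(C)CC3)c2c1` gives 79%; the step of a number 6 percentage points lower from compound 1 to compound 3 (within the scatter) and the step of a number 10 percentage points lower from compound 2 to compound 3 (within the scatter) both stay inside the scatter, so compound 3 holds the lowest of the three numbers only nominally, with every gap to the others within the usual spread.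

Compound 4 `C#Cc1ccc2ccn(CCN3CCCN(C)CC3)c2c1` differs from compound 3 by ethynyl in place of vinyl on an aromatic carbon. Among the compounds with values here, no measured step exchanges vinyl for ethynyl directly; the nearest guidance comes from the three exchanges at the same aromatic carbon, each of which stayed within the scatter. Compound 4 is therefore expected to stay close to compound 3, with an estimated step of a number 1 percentage points higher from compound 3 to compound 4 (within the scatter), meaning no step beyond the scatter. The estimate for compound 4 in this assay is 80%, within a range from 68% to 90%.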

Compound 4, a percentage reported as inhibition, at one concentration (the size of the read-out at that concentration, not a potency): 79%
Beside the measured number, compound 4's estimate is 1 percentage points above it; low and high end bracket the measured number.
By their numbers in this assay, from the lowest: compounds 3, 4, 1 and 2 (each within the scatter of the next).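

In this assay, replacing the double bond of vinyl with the triple bond of ethynyl on this aromatic carbon gives no change at the digits printed from compound 3 to compound 4 (within the scatter), an exchange between two all-carbon groups with the same count of heavy atoms. Ethynyl also compares with the other two groups in the same way as vinyl, with a number 10 percentage points lower from compound 2 to compound 4 (within the scatter) and a number 6 percentage points lower from compound 1 to compound 4 (within the scatter), so every step among chloro, trifluoromethyl, vinyl and ethynyl at this position stays within the scatter. Nothing available explains why these four groups read alike.

As far as these compounds go, whether this position would respond to an amine, a carboxylic acid or a longer chain such as butyl remains open. A reading at a single concentration also cannot show whether the potencies of these four compounds differ.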